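Cytotoxicity of acetylated-sugar triazole conjugates and alkyne precursors

The source may report more compounds than this note shows. Statements on the series, on what has been measured and on what is new or still open speak of the compounds shown alone.

Compound 1 `CC(=O)OC[C@H]1O[C@H](OC[C@@H](Cn2cc(CN(c3nc(-c4ccc(F)cc4)no3)C3CCCCC3)nn2)OC(C)=O)C=C[C@@H]1OC(C)=O` and compound 2 `CC(=O)OC[C@H]1O[C@H](OC[C@@H](Cn2cc(CN(c3nc(-c4cccc(C)c4)no3)C3CCCCC3)nn2)OC(C)=O)C=C[C@@H]1OC(C)=O` share a core carrying an acetylated sugar; compound 3 `C#CCN(c1nc(-c2ccc(F)cc2)no1)C1CCCCC1` and compound 4 `C#CCN(c1nc(-c2cccc(C)c2)no1)C1CCCCC1` carry the propargyl amine in its place. The difference between the two cores is not broken down here. In an ADME assay on HepG2 cells (Homo sapiens) for cytotoxicity, read by MTT assay, with a stated time of 48 h (a higher number here means that more compound is tolerated, a lower number that less compound is tolerated), compound 1 gives 28.8 ug/mL, compound 2 gives 39.2 ug/mL and compound 3 gives 41.1 ug/mL. The step of a 1.4-fold higher number from compound 1 to compound 2 (0.13 log units; within the scatter) belongs to the change (3-methylphenyl in place of 4-fluorophenyl on an aromatic carbon). Compound 4 carries the same change on the core of compound 3, (3-methylphenyl in place of 4-fluorophenyl on an aromatic carbon). Beside a 1.4-fold higher number from compound 1 to compound 2 (0.13 log units; within the scatter), a step of similar size, a 1.2-fold higher number from compound 3 to compound 4 (0.09 log units; within the scatter), is expected from compound 3 to compound 4, resting on the one earlier instance of this change and on compound 3 giving 41.1 ug/mL. Compound 4 is therefore estimated at 50 ug/mL in this assay, with a likely range from 30 ug/mL to 85 ug/mL.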

Compound 4, half-maximal cytotoxic concentration: 44.4 ug/mL
Estimate against measurement, compound 4: 1.1-fold (0.05 log units) above; low and high end bracket the measured number.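

Putting 3-methylphenyl in place of 4-fluorophenyl gives a 1.1-fold higher number from compound 3 to compound 4 (0.03 log units; within the scatter) in this assay. Set beside the earlier instance, the change reads alike on the two cores: the same change on two cores in this assay, a 1.4-fold higher number (0.13 log units; within the scatter) from compound 1 to compound 2 and a 1.1-fold higher number (0.03 log units; within the scatter) from compound 3 to compound 4, 1.3-fold (0.10 log units) apart, within the scatter of two such steps. Both steps lie within the scatter, so the change shows no measurable effect on either core in this assay; this does not establish a real effect that carries over, and two cores say nothing about other cores.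

The compounds shown hold only these two substituted phenyl groups at this place on the five-membered ring. On these data alone, whether an amine, a carboxylic acid or a longer alkyl chain there would give a step beyond the scatter on either core remains open.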